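Solubility notes on a pyrazole-biaryl series: cyano to carbamoyl

The source may hold more compounds than are shown below. What is called first, only, known or untested is meant among the compounds shown, and "the series" means these compounds.

Measured so far:
- compound 1, `Cn1cc(-c2cnc3occ(-c4cccc(C#N)c4)c3c2)cn1`: 600 nM
- compound 2, `Cn1cc(-c2cnc3[nH]cc(-c4ccc(C#N)cc4)c3c2)cn1`: 2000 nM
- compound 3, `Cn1cc(-c2cnc3[nH]cc(-c4cc(F)cc(C#N)c4)c3c2)cn1`: 500 nM

All three values come from a physicochemical assay for solubility, read by LC-MS, in phosphate buffer, measured as thermodynamic solubility, with a stated time of 24 h, at pH 7.4; on this read-out lower numbers stand for lower solubility and higher numbers for higher solubility. On this read-out compound 2 stands highest of the three; the nearest number, that of compound 1, and the furthest, that of compound 3, both sit below it by margins beyond the scatter, so compound 2 is the most soluble of the set so far. Compound 1 and compound 3 differ from compound 2 in more than one place, so their gaps are noted only as values.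

The step under study goes from compound 2 to compound 4, `Cn1cc(-c2cnc3[nH]cc(-c4ccc(C(N)=O)cc4)c3c2)cn1`. The change is carbamoyl in place of cyano on an aromatic carbon. Among the measured compounds shown here, no step between measured compounds isolates a change of this kind, so the size of the step is a judgement. The expectation for this assay is a modest rise, about a 2.3-fold higher number from compound 2 to compound 4 (0.35 log units; beyond the scatter), rather than none beyond the scatter. Compound 4 is estimated at 4500 nM, with a range from 1500 nM to 13000 nM.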

Compound 4, solubility: 3000 nM
For compound 4 the middle estimate is 1.5-fold (0.18 log units) above the measured one; the measured number falls inside the stated range.
By their numbers in this assay, from the lowest: compounds 3 and 1 (each within the scatter of the next); then compounds 2 and 4 (each within the scatter of the next).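

In this assay, this position now has a step that isolates one change: a 1.5-fold higher number from compound 2 to compound 4 (0.18 log units; within the scatter), with carbamoyl in place of cyano on an aromatic carbon, para to a large group. On this read-out, the hydrogen-bond donor of carbamoyl, which cyano lacks, and the extra heavy atom therefore come with no difference beyond the scatter between these two compounds. No measurement at hand accounts for this outcome.

Going by these compounds, whether a carboxylic acid, an amine or a longer chain on this aromatic carbon would give a step beyond the scatter remains open. Also open, on these data alone, is whether carbamoyl in place of cyano would read the same way on the core of compound 1 or alongside the fluorine of compound 3.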